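A second methoxy on the 3-methoxyphenyl group

A few compounds are considered here, and "the series" means these few. Any claim that something is new, unique, unknown or untested is made for them only; others in the source may bear on it.

Compound 1 `OC[C@H]1O[C@@H](n2cnc3c(NCc4ccccc4Cl)ncnc32)[C@H](O)[C@@H]1O`: 14500 nM
Compound 2 `COc1cccc(CNc2ncnc3c2ncn3[C@@H]2O[C@H](CO)[C@@H](O)[C@H]2O)c1`: 7600 nM

For the measured compounds named here, in a functional assay on CCRF-CEM cells (Homo sapiens) for antiproliferative activity, with a stated time of 72 h (a lower number here means a stronger inhibitor, a higher number a weaker inhibitor), compound 2 stands at 7600 nM and lies within the scatter of compound 1, the only other compound measured so far, so the two cannot be ranked. Compound 3 (`COc1cccc(CNc2ncnc3c2ncn3[C@@H]2O[C@H](CO)[C@@H](O)[C@H]2O)c1OC`) differs from compound 2 in one place, where 3-methoxyphenyl becomes 2,3-dimethoxyphenyl (methoxy in place of hydrogen on an aromatic carbon). Going by the values given here, no measured compound yet carries a second methoxy. Among the compounds with values here, only one measured step bears on this change by altering the same aromatic ring, and it stayed within the scatter (a 1.9-fold lower number from compound 1 to compound 2 (0.28 log units; within the scatter)). On this thin evidence, no step beyond the scatter is expected in this assay and no direction is favoured. The estimated change is a 1.1-fold higher number from compound 2 to compound 3 (0.02 log units; within the scatter) and would be too small to read as a real difference. Compound 3 is estimated at 8000 nM with an expected range of 3000 nM to 21000 nM for its measurement.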

Compound 3, half-maximal inhibitory concentration: > 166000 nM
Compound 3 ended at the assay's limit; the forecaster's own chance of this, stated with the estimate: 8%; middle value at least 20-fold (1.31 log units) away from the limit.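

For the compounds shown here, the one earlier change to this aromatic ring stayed within the scatter, so compound 1 and compound 2 gave no sign that the ring was sensitive to substitution. In this assay, however, a methoxy on the aromatic carbon ortho to a large group and ortho to a methoxy group gives an at least 21-fold higher number from compound 2 to compound 3 (1.33 log units; beyond the scatter), a large weakening from a single small addition. The 2,3-dimethoxyphenyl group also falls well short of the 2-chlorophenyl group, with an at least 11-fold higher number from compound 1 to compound 3 (1.05 log units; beyond the scatter), and compound 3 gives a limit rather than a number: the limit of > 166000 nM in this assay, at which 1 of the 3 values shown sits.

On these data alone, it remains open whether this position alone is responsible or whether the weakening needs both methoxy groups together, which a 2-methoxyphenyl group would separate. A smaller group such as hydroxy or an amine on the same carbon would show whether any substituent is accepted there.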